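The source may report more compounds than this note shows. Statements on the series, on what has been measured and on what is new or still open speak of the compounds shown alone.

Measured in a physicochemical assay for lipophilicity, read by NMR; on this read-out higher numbers stand for higher lipophilicity and lower numbers for lower lipophilicity:
- compound 1 `CC(F)(F)COc1ccc2[nH]ccc2c1`: 2.7
- compound 2 `OCCCCCF`: 0.52

Compound 1 stands higher of the two, and its gap to compound 2 lies beyond the scatter. Compound 3 `FC(F)CCOc1ccc2[nH]ccc2c1` has the same atoms as compound 1, joined differently: 2,2-difluoroethyl in place of 1,1-difluoroethyl on a saturated chain carbon bound to an oxygen on an aromatic ring, with 2,2-difluoroethyl in place of 1,1-difluoroethyl on a saturated chain carbon bound to an oxygen on an aromatic ring. Among the measured compounds shown here, no measured pair shows this change, so only a small step to lower numbers in this assay, close to the scatter, is expected. The expected change is a number 0.30 log units lower from compound 1 to compound 3 (within the scatter). Compound 3 is estimated at 2.4, within a range from 2.1 to 2.7.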

Compound 3, partition coefficient: 2.6
Beside the measured number, compound 3's estimate is 0.20 log units below it, within the range that was stated.
By their numbers in this assay, from the lowest: compound 2; then compounds 3 and 1 (each within the scatter of the next).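

Among the compounds shown here, at this position, on a saturated chain carbon bound to an oxygen on an aromatic ring, 2,2-difluoroethyl in place of 1,1-difluoroethyl gives a number 0.10 log units lower from compound 1 to compound 3 (within the scatter) in this assay, the first step read between compounds that differ in one place. On this read-out the two arrangements of the chain cannot be told apart. No evidence is available that bears on this result. From the compounds shown here alone, what remains open is how a plain propyl chain or a longer chain at this position would read against compound 1, and whether this same change would stay within the scatter on a different core.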